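Phenyl for pyridin-4-yl on the hydroxybenzamide amide series

The source may report more compounds than this note shows. Statements on the series, on what has been measured and on what is new or still open speak of the compounds shown alone.

Two compounds of the series carry measurements. Compound 1 `O=C(Nc1cc(C(F)(F)F)cc(C(F)(F)F)c1)c1cc(Br)c(-c2ccccc2)cc1O` in a functional assay on HL-60 cells (Homo sapiens) for cytotoxicity, read by luminescence and CellTiter-Glo, with a stated time of 3 days (a higher number here means a weaker inhibitor, a lower number a stronger inhibitor), gives 430 nM. Compound 2 `N#Cc1ccc(NC(=O)c2cc(-c3ccncc3)ccc2O)cc1` in this assay gives 5410 nM, the highest of the two numbers, and its distance from compound 1 is beyond the scatter. Among the compounds with values here, no step between measured compounds that differ in one place is recorded, so the two values stand side by side only.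

Compound 3 `N#Cc1ccc(NC(=O)c2cc(-c3ccccc3)ccc2O)cc1` awaits measurement in this assay. It differs from compound 2 in one place: phenyl in place of pyridin-4-yl on an aromatic carbon. Within the data shown here, no measured pair isolates this change, since compound 1 differs from compound 2 in several places at once. A small step toward a lower number, or none beyond the scatter, is expected. Compound 3 is estimated at 3000 nM, with an expected range from 1000 nM to 9000 nM. The expected step is a 1.8-fold lower number from compound 2 to compound 3 (0.26 log units; within the scatter).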

Compound 3, half-maximal inhibitory concentration: 1350 nM
For compound 3 the middle estimate is 2.2-fold (0.35 log units) above the measured one, and the stated range covers the measured number.
By their numbers in this assay, from the lowest: compound 1; then compound 3; then compound 2.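

Within the data shown here, the pair gives the first isolated reading of this position in this assay, where phenyl in place of pyridin-4-yl on the aromatic carbon para to a hydroxy group gives a 4.0-fold lower number from compound 2 to compound 3 (0.60 log units; beyond the scatter). The two groups match in heavy-atom count and differ in the ring nitrogen and its hydrogen-bond acceptor, so the number at this position responds to an exchange confined to that one ring atom, at least on the core shared by compound 2 and compound 3. No measurement on these compounds bears on why the number moves.

As far as these compounds go, what an amine or a carboxylic acid on this aromatic carbon would give stays open. Also open, from the compounds shown here alone, is whether the same exchange gives a comparable step on the core of compound 1.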